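Nitroxide aryl ethers with amino-acid tails: series notes

The compounds below may be only part of what the source reports. "The series", "measured", "known", "first", "only" and "open" are said of these compounds alone.

The series is read in a functional assay on PC-12 cells (Rattus norvegicus) for inhibition, read by MTT assay; on this read-out lower numbers stand for an effect already at smaller amounts and higher numbers for an effect only at larger amounts of compound. Compound 1 `CC(C)(C)OC(=O)N[C@@H](CCCCNC(=O)COc1ccc(C2=[N+]([O-])C(C)(C)C(C)(C)N2O)cc1)C(=O)O` gives 29300 nM in this assay; compound 2 `COC(=O)[C@@H](N)CCCNC(=N)NC(=O)COc1ccc(C2=NC(C)(C)C(C)(C)N2O)cc1` gives 33400 nM; compound 3 `COC(=O)[C@@H](N)CC(=O)NCCOc1ccc(C2=[N+]([O-])C(C)(C)C(C)(C)N2O)cc1` gives 47800 nM. Compound 3 sits alongside compound 1 and compound 2, its gaps to both falling within the scatter, so the three numbers are not separated from one another.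

Compound 4 `CC1(C)N(O)C(c2ccc(OCCNC(=O)CC[C@H](N)C(=O)O)cc2)=[N+]([O-])C1(C)C` is not yet measured. It differs from compound 3 by 2-amino-2-carboxyethyl in place of amino(methoxycarbonyl)methyl on a saturated chain carbon bound to a carbonyl carbon; the two have the same atoms, joined differently. Going by the values given here, no measured pair in the set shares this change, so nothing in the data sets its size. Given that compound 1, compound 2 and compound 3 lie together despite unlike tails, the step from compound 3 to compound 4 is expected to stay within the scatter, with no direction assigned: a 1.1-fold lower number from compound 3 to compound 4 (0.03 log units; within the scatter). Compound 4 is therefore estimated at 45000 nM in this assay, with a range from 20000 nM to 100000 nM.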

Compound 4, half-maximal effective concentration: 49600 nM
Compound 4: middle estimate off by 1.1-fold (0.04 log units), on the low side; low and high end bracket the measured number.
By their numbers in this assay, from the lowest: compounds 1, 2, 3 and 4 (each within the scatter of the next).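

Going by these compounds alone, this is the first one-place comparison: in this assay the step to 2-amino-2-carboxyethyl on the saturated chain carbon bound to a carbonyl carbon reads a 1.0-fold higher number from compound 3 to compound 4 (0.02 log units; within the scatter) and stays within the scatter. At this place, then, a methoxycarbonyl on the shorter chain and a free carboxy on the longer chain give numbers that are not separated, so neither the chain length nor the ester-to-acid exchange shows up as a shift when the two are made together. No supporting data bear on why this step is so small.

The two parts of the change remain unseparated, and amino(carboxy)methyl at this place, with the carboxylic acid on the shorter chain, would be needed to read them apart. As far as these compounds go, whether any tail at this place moves the number beyond the scatter also stays open.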